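Methoxy removal on the pyrazole-side ring: expectation for compound 4

A few compounds are considered here, and "the series" means these few. Any claim that something is new, unique, unknown or untested is made for them only; others in the source may bear on it.

Measured so far in a functional assay on HCT-15 cells (Homo sapiens) for cytotoxicity, read by sulforhodamine B assay, with a stated time of 48 h, tested at 0.1 uM; on this read-out lower numbers stand for a stronger effect and higher numbers for a weaker effect at the one concentration tested:
- compound 1, `COc1ccc(-c2cc(/C=C/C(=O)c3ccc(N)cc3)[nH]n2)cc1`, gives 100%
- compound 2, `COc1ccc(-c2cc(/C=C/C(=O)c3ccc(N)cc3)[nH]n2)cc1OC`, gives 95%
- compound 3, `COc1cc(C(=O)/C=C/c2cc(-c3cc(OC)c(OC)c(OC)c3)n[nH]2)cc(OC)c1OC`, gives 94%

All three numbers sit close together, and none can be called stronger or weaker than another within this set. From compound 2 to compound 1 the change is hydrogen in place of methoxy on an aromatic carbon, and the step it made was a number 5 percentage points higher from compound 2 to compound 1 (within the scatter). The difference between the core of compound 2 and the core of compound 3 is not broken down here.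

Compound 4, `COc1ccc(-c2cc(/C=C/C(=O)c3cc(OC)c(OC)c(OC)c3)[nH]n2)cc1OC`, is not yet measured. From compound 3 to compound 4 the change is hydrogen in place of methoxy on an aromatic carbon. Its surroundings differ from the earlier case in that the carbon is also meta to a methoxy group, so this is the same kind of change rather than the same one. Because the earlier step of a number 5 percentage points higher from compound 2 to compound 1 (within the scatter) stayed within the scatter, the step from compound 3 to compound 4 in this assay is expected to be similarly flat, about a number 3 percentage points higher from compound 3 to compound 4 (within the scatter). Compound 4 is estimated at 97%, with a range from 86% to 108%, resting on compound 3 giving 94%.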

Compound 4, a percentage reported as activity, at one concentration (the size of the read-out at that concentration, not a potency): 90%
For compound 4 the middle estimate is 7 percentage points above the measured one; measured number inside the range.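

In this assay, hydrogen in place of methoxy on an aromatic carbon gives a step of a number 4 percentage points lower from compound 3 to compound 4 (within the scatter). Set beside the earlier step on the other core, the two steps do not differ: the same change on two cores in this assay, a number 5 percentage points higher (within the scatter) from compound 2 to compound 1 and a number 4 percentage points lower (within the scatter) from compound 3 to compound 4, 9 percentage points apart, within the scatter of two such steps

Across these two cores, the change therefore leaves the number flat within the scatter at the one concentration tested, but this does not show that it has no effect, that the two cores would respond alike at other concentrations, or that the same would hold on a further core.

Still open, on these data alone, is whether a different group on this aromatic carbon, such as a hydroxyl, a chlorine atom or a longer ethoxy chain, would shift the number in this assay beyond the scatter. Also open, as far as these compounds go, is what a carboxylic acid in place of the amine of compound 1 would do in the same read-out.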